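Amide ring swap: a chloropyridine tested on a flavonol

The compounds below may be only part of what the source reports. "The series", "measured", "known", "first", "only" and "open" are said of these compounds alone.

Measured so far in a functional assay on HeLa cells (Homo sapiens) for antiproliferative activity, read by CCK-8 assay, with a stated time of 72 h; on this read-out lower numbers stand for stronger inhibition and higher numbers for weaker inhibition:
compound 1 `O=C(Nc1cccc(-c2oc3cc(-c4ccc(F)cc4)ccc3c(=O)c2O)c1)c1ccc(Cl)cc1` gives 3670 nM;
compound 2 `COc1ccccc1C(=O)Nc1cccc(-c2oc3cc(-c4ccc(F)cc4)ccc3c(=O)c2O)c1` gives 14100 nM;
compound 3 `O=C(Nc1cccc(-c2oc3cc(-c4ccc(F)cc4)ccc3c(=O)c2O)c1)c1cccc(F)c1` gives 8780 nM.

Among these three numbers compound 3 holds the second highest. Its nearest neighbour is compound 2, a gap that falls within the usual scatter, so the two cannot be ranked against each other; its furthest is compound 1, and the step of a 2.4-fold higher number from compound 1 to compound 3 (0.38 log units; beyond the scatter) lies beyond the scatter.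

Compound 4 `O=C(Nc1cccc(-c2oc3cc(-c4ccc(F)cc4)ccc3c(=O)c2O)c1)c1ccc(Cl)nc1` is the next member, not yet measured. It differs from compound 3 in one place: 6-chloropyridin-3-yl in place of 3-fluorophenyl on a carbonyl carbon.

Two earlier steps at this same carbonyl carbon bear on the question. The step of a 2.4-fold higher number from compound 1 to compound 3 (0.38 log units; beyond the scatter) was modest, and the step of a 1.6-fold lower number from compound 2 to compound 3 (0.21 log units; within the scatter) stayed within the scatter. Both show that changing the aromatic ring on this carbonyl shifts the number only a little, and compound 1 shows that a ring bearing chlorine gave the lowest number of the three. Compound 4 also carries chlorine, but on a ring with a nitrogen, for which no comparison exists here. The expected step is therefore small and downward, a 1.5-fold lower number from compound 3 to compound 4 (0.17 log units; within the scatter), with the chance of no change beyond the scatter kept open. For compound 4 the estimate in this assay is 6000 nM, with a range from 2500 nM to 15000 nM.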

Compound 4, half-maximal inhibitory concentration: 4080 nM
For compound 4 the middle estimate is 1.5-fold (0.17 log units) above the measured one; low and high end bracket the measured number.
By their numbers in this assay, from the lowest: compounds 1 and 4 (each within the scatter of the next); then compounds 3 and 2 (each within the scatter of the next).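

In this assay the change gives a 2.2-fold lower number from compound 3 to compound 4 (0.33 log units; beyond the scatter) and a 3.5-fold lower number from compound 2 to compound 4 (0.54 log units; beyond the scatter) once 6-chloropyridin-3-yl sits on the carbonyl carbon, so this ring separates from both the 3-fluorophenyl and the 2-methoxyphenyl rings. Against 4-chlorophenyl the comparison reads a 1.1-fold higher number from compound 1 to compound 4 (0.05 log units; within the scatter) and the two compounds cannot be told apart, which shows that this position accepts a ring nitrogen alongside chlorine without a measurable change in this pair. Nothing available here explains why these two chlorine-bearing rings give such similar numbers.

The compounds shown leave open how a plain phenyl ring, or a pyridine ring without chlorine, would compare on this carbonyl carbon. Also open, on these data alone, is what an amine, a carboxylic acid or a longer chain on this ring would do.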